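The source may hold more compounds than are shown below. What is called first, only, known or untested is meant among the compounds shown, and "the series" means these compounds.

Compound 3 `Cc1ccc(/C=C\C(=O)N2N=C(c3ccncc3)OC2c2c[nH]c3ccccc23)cc1` carries a 4-methylphenyl on a double-bonded chain carbon bound to a double-bonded chain carbon. In an ADME assay on HeLa cells (Homo sapiens) for cytotoxicity, read by MTT assay, with a stated time of 72 h (a lower number here means a stronger inhibitor of growth, a higher number a weaker inhibitor of growth), compound 3 reaches only a limit of the assay, > 30 ug/mL, not a number. Compound 1 `O=C(/C=C\c1ccccc1[N+](=O)[O-])N1N=C(c2ccncc2)OC1c1c[nH]c2ccccc12` bears a 2-nitrophenyl on that same chain carbon, and in this assay compound 1 likewise stops at a limit, > 30 ug/mL. Compound 2 `O=C(/C=C\c1ccc([N+](=O)[O-])cc1)N1N=C(c2ccncc2)OC1c1c[nH]c2ccccc12` bears a 4-nitrophenyl there; in this assay compound 2 also gives only a limit, > 30 ug/mL. Among the compounds with values here, compound 3 thus stands exactly where the other two stand, at the limit of > 30 ug/mL in this assay, at which 3 of the 3 values shown sit, and no measured compound is separated from another. The steps a step that the two limits leave unreadable from compound 1 to compound 2, a step that the two limits leave unreadable from compound 1 to compound 3 and a step that the two limits leave unreadable from compound 2 to compound 3 are all left without a readable size by the two limits at their ends.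

Compound 4 `O=C(/C=C\c1ccccc1F)N1N=C(c2ccncc2)OC1c1c[nH]c2ccccc12` differs from compound 3 in one place: 2-fluorophenyl in place of 4-methylphenyl on a double-bonded chain carbon bound to a double-bonded chain carbon. The three measured steps that touch this part of the molecule are the ones that bear on the change, and none of them has a readable size, so no step beyond the scatter is expected in this assay in either direction; the expected step is a step that the limit leaves unreadable from compound 3 to compound 4. Compound 4 is therefore expected to give about 45 ug/mL in this assay, within a range of 20 ug/mL to 120 ug/mL, and most probably to be reported once more only as a limit.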

Compound 4, concentration for 50% growth inhibition: > 30 ug/mL
Compound 4: no number, only a limit; the forecaster's own chance of this, stated with the estimate: 80%; the middle value is on the limit's open side.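

In this assay compound 4 gives > 30 ug/mL, which is a limit of the assay and not a number. No new step can be read between compound 4 and compound 1, compound 2 or compound 3, all of which stop at the same point: the limit of > 30 ug/mL in this assay, at which 4 of the 4 values shown sit.

The compounds shown leave open whether any of these aryl changes on the chain carbon alters growth inhibition in this assay, and by how much.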